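Swapping a Large Side Group for a Small One

The compounds below may be only part of what the source reports. "The series", "measured", "known", "first", "only" and "open" are said of these compounds alone.

Values in a functional assay on HeLa cells (Homo sapiens) for inhibition, read by MTT assay, with a stated time of 48 h; on this read-out lower numbers stand for stronger inhibition and higher numbers for weaker inhibition:
- compound 1 `CCOC(=O)C1=C(N/C=N/c2cccnc2Cl)Nc2[nH]nc(C)c2C1c1ccc(N(C)C)cc1`: 4630 nM
- compound 2 `CCOC(=O)C(=NNC1=C(C(=O)OCC)C(c2ccc(N(C)C)cc2)c2c(C)n[nH]c2N1)C(=O)OCC`: 83800 nM
- compound 3 `CCOC(=O)C1=C(N/N=C(/Cl)C#N)Nc2[nH]nc(C)c2C1c1ccc(N(C)C)cc1`: not yet measured

Of the two measured compounds, compound 2 has the higher number, at 83800 nM, and is therefore the weaker inhibitor in this assay. Compound 3 keeps the shared core and changes one group, on an amine nitrogen whose other neighbours are: double-bonded ring carbon. The change is a group of 5 heavy atoms (2 carbon, 2 nitrogen, 1 chlorine; no ring) in place of a group of 12 heavy atoms (7 carbon, 1 nitrogen, 4 oxygen; no ring), on an amine nitrogen.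

Within the data shown here, only one measured step bears on this: an 18-fold higher number from compound 1 to compound 2 (1.26 log units; beyond the scatter). That large rise came with the arrival of the same group of 12 heavy atoms that now leaves. Removing it may therefore undo part of that rise, so a lower number is expected. A full return is not assumed, since the entering group has no ring, unlike the group it replaced in that step, and a single step is thin evidence. The expected change is a 5.6-fold lower number from compound 2 to compound 3 (0.75 log units; beyond the scatter). For compound 3 the estimated value is 15000 nM, with an expected range of 3500 nM to 60000 nM.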

Compound 3, half-maximal inhibitory concentration: 26200 nM
For compound 3 the middle estimate is 1.7-fold (0.24 log units) below the measured one; low and high end bracket the measured number.
By their numbers in this assay, from the lowest: compound 1; then compound 3; then compound 2.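

In this assay, a 3.2-fold lower number from compound 2 to compound 3 (0.50 log units; beyond the scatter) when the group of 12 heavy atoms on the amine nitrogen gives way to the group of 5 heavy atoms, so a much smaller group with no ring lowers the number at this position. The group of 9 heavy atoms with its six-membered aromatic ring still gives the lowest number of the three, since a 5.7-fold higher number from compound 1 to compound 3 (0.75 log units; beyond the scatter), which means that the numbers here do not simply follow the heavy-atom count: the group of middle size gives the lowest number, and the largest group gives the highest. No outside measurement is available to explain either step.

The compounds shown leave open whether the aromatic ring, its ring nitrogen or its chlorine matters most, and a plain phenyl group or a 3-pyridyl group without the chlorine would help to separate these parts. They also leave open whether the nitrile or the chlorine in the group of compound 3 matters, which a comparison with a simple methyl or acetyl group on the same nitrogen could begin to address.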